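A few compounds are considered here, and "the series" means these few. Any claim that something is new, unique, unknown or untested is made for them only; others in the source may bear on it.

Of the compounds shown here, two have been measured in an assay on CHO cells for displacement of a labelled ligand from adenosine receptor A1 (Homo sapiens); on this read-out higher numbers stand for weaker inhibition and lower numbers for stronger inhibition. Compound 1 `CCNC(=O)[C@H]1O[C@@H](n2cnc3c(NC)nc(-n4cc(Cc5ccccc5)nn4)nc32)[C@H](O)[C@@H]1O` gives 510 nM, and compound 2 `CCNC(=O)[C@H]1O[C@@H](n2cnc3c(NC)nc(-n4cc(CC5CCCC5)nn4)nc32)[C@H](O)[C@@H]1O` gives 1250 nM. Compound 2 therefore shows the higher of the two numbers, that is, the weaker binding; the step of a 2.5-fold higher number from compound 1 to compound 2 (0.39 log units; beyond the scatter) describes how the number rose when cyclopentyl replaced phenyl on the saturated chain carbon bound to an aromatic carbon.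

Compound 3 `CCNC(=O)[C@H]1O[C@@H](n2cnc3c(NC)nc(-n4ccnn4)nc32)[C@H](O)[C@@H]1O` goes one step further in the same region of the molecule: hydrogen in place of cyclopentylmethyl on an aromatic carbon. The whole cyclopentylmethyl group is removed, leaving only a hydrogen on that aromatic carbon. Among the measured compounds shown here, no measured step covers this exact change. For the measured compounds named here, the one step that does exist, from compound 1 to compound 2, shows that swapping one group for another on this carbon already moved the number modestly; removing the group altogether is a larger change, and its effect on this assay is uncertain. Loss of the group is expected to weaken binding somewhat, so for compound 3 a step of a 2.0-fold higher number from compound 2 to compound 3 (0.30 log units; within the scatter) is estimated, and the expected value for compound 3 is 2500 nM, within a range from 800 nM to 8000 nM.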

Compound 3, inhibition constant: 590 nM
Compound 3: the middle estimate sits 4.2-fold (0.63 log units) above what was measured; measured number below the stated range.
By their numbers in this assay, from the lowest: compounds 1 and 3 (each within the scatter of the next); then compound 2.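

In this assay the move from cyclopentylmethyl to a bare hydrogen on the aromatic carbon of the five-membered ring gives a 2.1-fold lower number from compound 2 to compound 3 (0.33 log units; beyond the scatter) and so brings stronger inhibition, which shows that this position does not need a large group for binding at this level. Replacing benzyl with hydrogen gives a 1.2-fold higher number from compound 1 to compound 3 (0.06 log units; within the scatter) and leaves compound 1 and compound 3 indistinguishable, so the benzyl group offers no measurable gain over hydrogen here. Among these three compounds, only the cyclopentylmethyl group of compound 2 stands apart, and nothing available explains why.

The compounds shown leave open what a small group such as methyl, or a polar one such as aminomethyl or hydroxymethyl, would do on this same carbon. From the compounds shown here alone, it also remains open whether a six-membered carbon ring on the same single-carbon link, as in cyclohexylmethyl, or a longer chain ending in phenyl, would stay level with compound 1 and compound 3 or move toward compound 2.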